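A Methoxybenzylamino Group in Place of Methylpiperazine

The source may report more compounds than this note shows. Statements on the series, on what has been measured and on what is new or still open speak of the compounds shown alone.

The work compares two measured compounds in a functional assay on L02 cells (Homo sapiens) for inhibition, read by Griess assay, with stated times of 1 h and 24 h; a lower number here means a stronger inhibitor, a higher number a weaker inhibitor. Compound 1 `CCCc1nn(C)c2c(NC(C)C)nc(/C=C/c3ccc[n+]([O-])c3)nc12` gives 324000 nM. Compound 2 `COc1cc(/C=C/c2nc(N3CCN(C)CC3)c3sccc3n2)cc(OC)c1OC` gives > 1000000 nM, which is the limit of > 1000000 nM in this assay, at which 1 of the 2 values shown sits, and not a measured number. Compound 3 `COc1ccc(CNc2nc(/C=C/c3cc(OC)c(OC)c(OC)c3)nc3ccsc23)cc1` differs from compound 2 by (4-methoxybenzyl)amino in place of 4-methylpiperazin-1-yl on an aromatic carbon. No step between measured compounds is shown, so the size of this change in this assay cannot be read from data; any shift is expected to stay near the scatter, with weak inhibition remaining likely. Compound 3 is estimated at 600000 nM, expected between 150000 nM and 3000000 nM. The expected step is an at least 1.6-fold lower number from compound 2 to compound 3 (0.22 log units; that floor lies within the scatter).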

Compound 3, half-maximal inhibitory concentration: > 1000000 nM
Compound 3: a limit, no number (the forecaster's own chance of this, stated with the estimate: 45%); middle value at least 1.6-fold (0.22 log units) from the limit.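

In this assay no step can be read from compound 2 to compound 3, as each of the two stands at a limit: the limit of > 1000000 nM in this assay, at which 2 of the 3 values shown sit. The compounds shown leave open whether (4-methoxybenzyl)amino in place of 4-methylpiperazin-1-yl changes inhibition at all, and by how much.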